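This account rests on a few compounds, and the source may have more. Where it says the series, first, only, none or still open, it means among the compounds named here.

Compound 1, `NS(=O)(=O)c1ccc(S(=O)(=O)Nc2cccc(-c3nc(-c4ccc(NC(=O)c5cccnc5)cc4Cl)no3)c2)cc1`: > 10000 nM
Compound 2, `CCNC(=O)Nc1ccc(S(=O)(=O)Nc2cccc(-c3nc(-c4ccc(NC(=O)c5cccnc5)cc4Cl)no3)c2)cc1`: 3100 nM

For the measured compounds named here, in a functional assay on MDA-MB-231 cells (Homo sapiens) for antiproliferative activity, read by MTT assay, with a stated time of 72 h (a higher number here means a weaker inhibitor, a lower number a stronger inhibitor), compound 2 gives 3100 nM, the only plain number among the two. For compound 1 the result > 10000 nM is a limit of the assay, not a number (the limit of > 10000 nM in this assay, at which 1 of the 2 values shown sits). Going by the values given here, the one measured step, an at least 3.2-fold lower number from compound 1 to compound 2 (0.50 log units; beyond the scatter), changed a group on an aromatic carbon. Compound 3, `O=C(Nc1ccc(-c2noc(-c3cccc(NS(=O)(=O)c4ccc(NC(=O)N5CCOCC5)cc4)c3)n2)c(Cl)c1)c1cccnc1`, instead carries morpholin-4-yl in place of ethylamino on a carbonyl carbon, a change at a different place with different groups, so that step gives little guidance. Compound 3 is therefore expected to stay close to compound 2, a step of a 1.0-fold lower number from compound 2 to compound 3 (0.01 log units; within the scatter). The estimate for compound 3 is 3000 nM, ranging from 1200 nM to 8000 nM.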

Compound 3, half-maximal inhibitory concentration: > 10000 nM
Compound 3: no number, only a limit; the forecaster's own chance of this, stated with the estimate: 15%; middle value at least 3.3-fold (0.52 log units) away from the limit.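

In this assay, morpholin-4-yl in place of ethylamino on the carbonyl carbon is not a silent swap, giving an at least 3.2-fold higher number from compound 2 to compound 3 (0.50 log units; beyond the scatter), so the group on this carbon affects the read-out. The result for compound 3 is a limit of the assay, not a number: the limit of > 10000 nM in this assay, at which 2 of the 3 values shown sit. The step between compound 1 and compound 3 cannot be read.

Going by these compounds, it remains open whether the loss follows from the ring itself or from its oxygen, which piperidin-1-yl on the same carbon could separate. Whether a longer chain, such as propylamino, would lower the number is also unknown.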